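The source may report more compounds than this note shows. Statements on the series, on what has been measured and on what is new or still open speak of the compounds shown alone.

Of the compounds shown here, two with a shared core have been tested in an ADME assay on Vero cells (Chlorocebus sabaeus) for cytotoxicity, read by MTT assay, with a stated time of 72 h; a higher number here means a weaker inhibitor, a lower number a stronger inhibitor. Compound 1, `O=C(NNC(=O)c1ccc(-n2cccc2)cc1)c1ccc(Br)cc1`, gives 186000 nM in this assay. Compound 2, `Clc1ccc(-c2nnc(-c3ccc(-n4cccc4)cc3)o2)cc1`, gives 253000 nM in this assay. Among the measured compounds shown here, of the two numbers, that of compound 2 is the higher one, yet its only neighbour is compound 1 and the gap between them lies within the scatter of repeated measurements, so the two values show no difference that can be read as real.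

The next compound, compound 3, `Brc1ccc(-c2nnc(-c3ccc(-n4cccc4)cc3)o2)cc1`, has not yet been measured in this assay. It differs from compound 2 at a single point: bromo in place of chloro on an aromatic carbon. The change sits on an aromatic carbon of a six-membered aromatic ring of carbon only, para to a large group. For the measured compounds named here, no measured pair here shows the effect of such a swap. Since compound 1 and compound 2 sit so close together in this assay and the structural change is small, the step of a 1.1-fold lower number from compound 2 to compound 3 (0.04 log units; within the scatter) is expected to be none beyond the scatter, in either direction. Compound 3 is accordingly estimated at 230000 nM in this assay, with a range from 120000 nM to 450000 nM.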

Compound 3, half-maximal inhibitory concentration: 260000 nM
Compound 3: middle estimate off by 1.1-fold (0.05 log units), on the low side; measured number inside the range.
By their numbers in this assay, from the lowest: compounds 1, 2 and 3 (each within the scatter of the next).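

In this assay, among the compounds shown here, bromo in place of chloro on an aromatic carbon, para to a large group, gives a 1.0-fold higher number from compound 2 to compound 3 (0.01 log units; within the scatter), the first measured swap at this position. The 4-chlorophenyl and 4-bromophenyl forms of this core therefore cannot be told apart here, so this exchange of one halogen for the other leaves no real mark on the read-out. Nothing at hand explains this result or bears on it.

The compounds shown leave open whether this position responds at all to a group other than these two halogens, such as an amine, a carboxylic acid or a longer chain, any of which would test it far more severely than this swap did. They also leave open whether chloro in place of bromo on the core of compound 1 would likewise stay within the scatter, or whether the outcome seen from compound 2 to compound 3 holds only for the shared core of those two compounds.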